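The source may hold more compounds than are shown below. What is called first, only, known or untested is meant among the compounds shown, and "the series" means these compounds.

Working notes on the series. The three measured compounds share a core and differ from one another only away from the piperidine end. In an assay on HEK293 cells for binding affinity to 5-hydroxytryptamine receptor 7 (Homo sapiens), read by radioligand binding (a higher number here means a weaker inhibitor, a lower number a stronger inhibitor), compound 1 `CC1CCN(CC[C@H]2CCCN2S(=O)(=O)c2ccc3cc[nH]c3c2)CC1` gives 2.4 nM. Compound 2 `CC1CCN(CC[C@H]2CCCN2S(=O)(=O)c2ccc3c[nH]nc3c2)CC1` gives 6.46 nM in this assay, and compound 3 `CC1CCN(CC[C@H]2CCCN2S(=O)(=O)c2ccc3[nH]cnc3c2)CC1` gives 6.46 nM in this assay. Compound 1 thus stands lowest of the three numbers, beyond the scatter from both others. Compound 4 `O=S(=O)(c1ccc2cc[nH]c2c1)N1CCC[C@@H]1CCN1CCC(c2c[nH]c3ccccc23)CC1` is not yet measured in this assay; against compound 1 the change is 1H-indol-3-yl in place of methyl on a saturated ring carbon. Within the data shown here, no measured pair isolates this change, so the expectation rests on the change alone: a small step, within the scatter or a modest rise in the number. The expected step is a 1.9-fold higher number from compound 1 to compound 4 (0.27 log units; within the scatter). Compound 4 is estimated at 4.5 nM, with a range of 1.2 nM to 18 nM.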

Compound 4, inhibition constant: 0.676 nM
Estimate against measurement, compound 4: 6.7-fold (0.82 log units) above; measured number outside the range, below it.
By their numbers in this assay, from the lowest: compound 4; then compound 1; then compounds 2 and 3 (each within the scatter of the next).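

In this assay, the saturated ring carbon three ring bonds from the ring nitrogen takes 1H-indol-3-yl in place of methyl with a 3.6-fold lower number from compound 1 to compound 4 (0.55 log units; beyond the scatter), so this position tolerates a far larger group with a real gain. Compounds 1, 2 and 3 all carry methyl here and could say nothing about this position.

Going by these compounds, it remains open whether phenyl or benzyl on the same carbon would give a similar step without the ring nitrogen of 1H-indol-3-yl, and whether the change carries over to compound 2 and compound 3. No supporting data bear on why the number falls.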